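A Second Fluorine on the Carbonyl Substituent

The source may hold more compounds than are shown below. What is called first, only, known or untested is meant among the compounds shown, and "the series" means these compounds.

Of the compounds shown here, three sharing one core have been tested in a functional assay on isolated protein for inhibition of Glucose-dependent insulinotropic receptor (Rattus norvegicus), read by HTRF and cAMP accumulation; a lower number here means a smaller maximal response, a higher number a larger maximal response. Compound 1 `Cc1nc(S(C)(=O)=O)ccc1Oc1ncnc(OC2CCN(C(=O)SC(C)C)CC2)c1F` gives 81%. Compound 2 `Cc1nc(S(C)(=O)=O)ccc1Oc1ncnc(OC2CCN(C(=O)SC3CC3)CC2)c1F` gives 80%. Compound 3 `Cc1nc(S(C)(=O)=O)ccc1Oc1ncnc(OC2CCN(C(=O)C(C)(C)F)CC2)c1F` gives 74%, the smallest of the three numbers, though the step of a number 7 percentage points lower from compound 1 to compound 3 (within the scatter) and the step of a number 6 percentage points lower from compound 2 to compound 3 (within the scatter) both lie within the scatter, as does the step of a number 1 percentage points lower from compound 1 to compound 2 (within the scatter). All three changes sit on the carbonyl carbon attached to the amide-type nitrogen in a ring, and none of them moved the maximal response beyond the scatter.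

Compound 4 `CCC(F)(F)C(=O)N1CCC(Oc2ncnc(Oc3ccc(S(C)(=O)=O)nc3C)c2F)CC1` is not yet measured. It differs from compound 3 in this way: 1,1-difluoropropyl in place of 1-fluoro-1-methylethyl on a carbonyl carbon. The change is again a swap of a small group on the same carbonyl carbon, and the measured steps at that position, from compound 1 to compound 2 and from compound 1 or compound 2 to compound 3, were all within the scatter. Compound 4 is therefore expected to give a maximal response close to that of compound 3, with the step of a number 1 percentage points higher from compound 3 to compound 4 (within the scatter) expected to stay within the scatter. The estimate for compound 4 in this assay is 75%, with a range from 62% to 88%.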

Compound 4, largest response reached (reported as efficacy), in percent of the reference or control that the assay uses: 90%
Compound 4: the middle estimate sits 15 percentage points below what was measured; the whole stated range lies below it.
By their numbers in this assay, from the lowest: compounds 3, 2, 1 and 4 (each within the scatter of the next, the first and the last beyond it).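

Within the data shown here, at the carbonyl carbon, 1,1-difluoropropyl in place of 1-fluoro-1-methylethyl gives the first step at this position in this assay to lie beyond the scatter, a step of a number 16 percentage points higher from compound 3 to compound 4 (beyond the scatter) that shows the maximal response can respond to the group placed here, if only modestly. The result does not set compound 4 apart from the two compounds with sulfur-linked groups, with a number 10 percentage points higher from compound 2 to compound 4 (within the scatter) and a number 9 percentage points higher from compound 1 to compound 4 (within the scatter) both printed as within the scatter, so the only separation in this set is that between compound 3 and compound 4. The entering group has two fluorines where the leaving group has one, and the carbon count stays the same, but no measurement shown accounts for the step.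

The compounds shown leave open whether the second fluorine or the arrangement of the carbon chain goes with the higher number, as the single step changes both together. Also open, going by these compounds, is how 1,1-difluoroethyl, 1,1-difluorobutyl or trifluoromethyl on the same carbonyl carbon would read in this assay and whether any of them would stand beyond the scatter from compound 4.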